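Carbamate to piperidinylmethyl amide on the shared core

The source may report more compounds than this note shows. Statements on the series, on what has been measured and on what is new or still open speak of the compounds shown alone.

The series keeps one core, seen in compound 1 `CCCCNC(=O)Nc1cccc2c1CN(C)CC2c1ccc(C)cc1`, and varies the group on the ring nitrogen substituent and the aryl group. In a functional assay on the whole organism for inhibition, with Mus musculus as the target (on this read-out lower numbers stand for an effect already at smaller amounts and higher numbers for an effect only at larger amounts of compound), compound 1 gives 40 mg/kg. Compound 2 `CCOC(=O)Nc1cccc2c1CN(C)CC2c1ccc(F)cc1` gives 3.5 mg/kg in this assay, and compound 3 `CCCCOC(=O)Nc1cccc2c1CN(C)CC2c1ccccc1` gives 4 mg/kg in this assay. Among these three numbers compound 3 stands second highest; its nearest neighbour is compound 2, whose number lies within the scatter of it, and its furthest is compound 1, whose number is higher by a margin beyond the scatter.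

Compound 4 `CN1Cc2c(NC(=O)CN3CCCCC3)cccc2C(c2ccccc2)C1` has not been measured in this assay. It differs from compound 3 by (piperidin-1-yl)methyl in place of butoxy on a carbonyl carbon. Among the measured compounds shown here, no measured pair in the set shows this change, so the size and direction of the step cannot be read from the data. Compound 2 and compound 3 sit close together, while compound 1 sits beyond the scatter above them; whether compound 4 follows either is open. Compound 4 is therefore expected at 8 mg/kg, with a range of 3 mg/kg to 30 mg/kg. The estimated step of a 2.0-fold higher number from compound 3 to compound 4 (0.30 log units; within the scatter) means a number expected somewhat higher, of a size within the scatter or just beyond it.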

Compound 4, dose for half-maximal effect: about 65 mg/kg
The estimate for compound 4 lay 8.1-fold (0.91 log units) below the measured number; measured number above the stated range.
By their numbers in this assay, from the lowest: compounds 2 and 3 (each within the scatter of the next); then compounds 1 and 4 (each within the scatter of the next).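

In this assay, among the compounds shown here, (piperidin-1-yl)methyl in place of butoxy on a carbonyl carbon gives a 16-fold higher number from compound 3 to compound 4 (1.21 log units; beyond the scatter), a large step beyond the scatter and the only step that can be read at this position. The group on this carbonyl carbon therefore matters a great deal on the shared core, and for this pair the change moves the effect to much larger doses, although a single pair gives no trend. Nothing measured on these compounds bears on the reason for the size of this step, so it remains an observation without an explanation.

The change replaces an open butoxy chain joined through oxygen with a carbon-joined group carrying a six-membered ring and a nitrogen, and the compounds shown leave open which of these features goes with the step; a cyclohexylmethyl group or an open-chain diethylaminomethyl group on the same carbonyl carbon would help separate them. Also open, on these data alone, is whether a step of this size would recur with the aryl groups of compound 1 and compound 2.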